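The compounds below may be only part of what the source reports. "The series", "measured", "known", "first", "only" and "open" are said of these compounds alone.

Measured so far in a functional assay for inhibition, with Homo sapiens as the target; on this read-out lower numbers stand for stronger inhibition and higher numbers for weaker inhibition:
- compound 1 `CC(C)(C)Sc1c(CC(C)(C)C(=O)O)n(Cc2ccc(Cl)cc2)c2ccc(CCc3ccc4ccccc4n3)cc12`: 4 nM
- compound 2 `CC(C)(C)Sc1c(CC(C)(C)C(=O)O)n(Cc2ccc(Cl)cc2)c2ccc(OCc3cccnc3)cc12`: 8 nM

Within the data shown here, of the two numbers, that of compound 2 is the higher, though the single step, a 2.0-fold higher number from compound 1 to compound 2 (0.30 log units; within the scatter), lies within the scatter. Compound 3 `CC(COc1ccc2c(c1)c(SC(C)(C)C)c(CC(C)(C)C(=O)O)n2Cc1ccc(Cl)cc1)c1ccccn1` differs from compound 2 by 1-(pyridin-2-yl)ethyl in place of pyridin-3-yl on a saturated chain carbon bound to an oxygen on an aromatic ring. The measured step of a 2.0-fold higher number from compound 1 to compound 2 (0.30 log units; within the scatter) changed the group on the aromatic carbon rather than the saturated chain carbon bound to the oxygen, so it bears only loosely on this change; with that step within the scatter, no shift beyond the scatter is expected, a 1.3-fold higher number from compound 2 to compound 3 (0.10 log units; within the scatter). Compound 3 is therefore estimated at 10 nM, between 3 nM and 35 nM.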

Compound 3, half-maximal inhibitory concentration: 4 nM
Estimate against measurement, compound 3: 2.5-fold (0.40 log units) above, and the stated range covers the measured number.
By their numbers in this assay, from the lowest: compounds 1, 3 and 2 (each within the scatter of the next).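

In this assay the move to 1-(pyridin-2-yl)ethyl on the saturated chain carbon bound to the oxygen gives a 2.0-fold lower number from compound 2 to compound 3 (0.30 log units; within the scatter) and shows that this position accepts a larger group without a shift beyond the scatter. Among these compounds, the comparison with the first compound gives no change at the digits printed from compound 1 to compound 3 (within the scatter) and shows that these two different groups on the aromatic carbon read alike. No measurement shown accounts for either step.

The change from pyridin-3-yl to 1-(pyridin-2-yl)ethyl leaves the contributions of ring attachment and ethyl link unseparated. As far as these compounds go, whether an amine or a carboxylic acid at this position would shift the number remains open.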